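A few compounds are considered here, and "the series" means these few. Any claim that something is new, unique, unknown or untested is made for them only; others in the source may bear on it.

Compound 1 `C/C(=N\N(Cc1ccccc1)Cc1ccccc1)c1ccccc1`: 25000 nM
Compound 2 `c1ccc(CN(Cc2ccccc2)/N=C2\CCCc3ccccc32)cc1`: 25000 nM
Compound 3 `COc1ccccc1/C=N/N(Cc1ccccc1)Cc1ccccc1`: > 100000 nM

All three were tested in an assay on liver (Sus scrofa) for inhibition of glucose-6-phosphatase catalytic subunit 1 (Homo sapiens), using microsomes; a lower number here means a stronger inhibitor, a higher number a weaker inhibitor. In this assay compound 1 gives 25000 nM, and compound 2 gives 25000 nM; these two values lie within the usual scatter of each other, so no order can be drawn between them. Compound 3 is different: its value of > 100000 nM is a limit of this assay, not a number. It sits at the limit of > 100000 nM in this assay, at which 1 of the 3 values shown sits, and so compound 3 is only known to be at the weak end of what was measured.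

Compound 4 `Clc1ccc(/C=N/N(Cc2ccccc2)Cc2ccccc2)cc1Cl` has not yet been measured. It differs from compound 3 in one place: 3,4-dichlorophenyl in place of 2-methoxyphenyl on a carbon with a double bond to nitrogen. For the measured compounds named here, no step between two measured compounds covers this kind of exchange, and since compound 3 only gives a limit, the size of the step cannot be anchored. For compound 4 the expected step is in the direction of stronger inhibition, roughly towards the values of compound 1 and compound 2, as an at least 2.0-fold lower number from compound 3 to compound 4 (0.30 log units; that floor lies within the scatter), though with wide uncertainty. Compound 4 is therefore estimated at 50000 nM, with a range from 15000 nM to 200000 nM, and a real chance that this assay again reports only a limit.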

Compound 4, half-maximal inhibitory concentration: 2000 nM
Compound 4: the middle estimate sits 25-fold (1.40 log units) above what was measured; the measured number lies below the stated range.
By their numbers in this assay, from the lowest: compound 4; then compounds 1 and 2 (each within the scatter of the next). At a limit, above all of these: compound 3.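

For the compounds shown here, on the carbon with a double bond to nitrogen, the earlier compounds offered no step to read, and this exchange gives the first one in this assay: 3,4-dichlorophenyl in place of 2-methoxyphenyl gives an at least 50-fold lower number from compound 3 to compound 4 (1.69 log units; beyond the scatter). So the group at this place can change the read-out by a large margin, at least for this pair, which share the rest of their structure. That size is only a floor, and the full step stays unknown, since the value of compound 3 is a limit of the assay and not a number: the limit of > 100000 nM in this assay, at which 1 of the 4 values shown sits.

The exchange removes a methoxy group and brings in two chlorines at once, so this pair cannot show which of those changes carries the step, and it gives no measured property that would explain it. On these data alone, it also remains open how a ring with a single chlorine, or one carrying an amine or a carboxylic acid in place of the chlorines, would read in this assay.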